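The source may hold more compounds than are shown below. What is called first, only, known or untested is meant among the compounds shown, and "the series" means these compounds.

Three members of this series carry numbers from an assay on T-REx-293 cells for inhibition of potassium channel subfamily T member 1 (Homo sapiens), read by patch clamp; on this read-out lower numbers stand for stronger inhibition and higher numbers for weaker inhibition. Compound 1 `Cc1cccc(-c2nc(C(C)NC(=O)c3cc(C(F)(F)F)nn3C)no2)c1` gives 977 nM. Compound 2 `C[C@H](NS(=O)(=O)c1cc(C(F)(F)F)nn1C)c1nc(-c2cccc(F)c2)no1` is known only by a limit of this assay, > 30000 nM; one of the three values shown sits at this limit (the limit of > 30000 nM in this assay, at which 1 of the 3 values shown sits). Compound 3 `COc1cc(-c2noc([C@H](C)NC(=O)c3cc(C(F)(F)F)nn3C)n2)ccn1` gives 27 nM, the lowest of the two numbers measured, and its gap to compound 1 lies well beyond the scatter of repeated measurements. Nothing measured yet connects two compounds that differ in a single place, so no step size within the series is known.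

Compound 4 `CO[C@@H](C)c1cc(-c2noc([C@H](C)NC(=O)c3cc(C(F)(F)F)nn3C)n2)ccn1` is the next member to be measured in this assay. Against compound 3 the change is 1-methoxyethyl in place of methoxy on an aromatic carbon. Among the compounds with values here, the change adds two carbons at the ring position while keeping the oxygen, and no measured pair shows what such an enlargement does here. A small step, if any, is expected, with a 1.5-fold higher number from compound 3 to compound 4 (0.17 log units; within the scatter) staying within the usual scatter. Compound 4 is therefore estimated at 40 nM in this assay, with a range from 12 nM to 150 nM.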

Compound 4, half-maximal inhibitory concentration: 744 nM
Beside the measured number, compound 4's estimate is 19-fold (1.27 log units) below it, outside the stated range (above it).
By their numbers in this assay, from the lowest: compound 3; then compounds 4 and 1 (each within the scatter of the next). At a limit, above all of these: compound 2.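

Within the data shown here, the only single-place step is large: in this assay, 1-methoxyethyl in place of methoxy gives a 28-fold higher number from compound 3 to compound 4 (1.44 log units; beyond the scatter), on an aromatic carbon next to the ring nitrogen. This position therefore responds strongly to what is attached there, and keeping the oxygen and the hydrogen-bond acceptor count does not preserve the number of compound 3. No measurement shown bears on the cause of this step.

With a single pair at this position, the added carbons, the branching and the defined stereocentre cannot be separated. Going by these compounds, it remains open how an ethoxy group, a methoxymethyl group, an amine or the opposite stereoisomer of the 1-methoxyethyl group would read at this position.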